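This account rests on a few compounds, and the source may have more. Where it says the series, first, only, none or still open, it means among the compounds named here.

In an ADME assay on HEK293 cells (Homo sapiens) for cytotoxicity, read by luminescence, with a stated time of 72 h (on this read-out lower numbers stand for an effect already at smaller amounts and higher numbers for an effect only at larger amounts of compound), compound 1 (`CCOC(=O)c1c(-c2cccc(OC)c2)[nH]c2cc(OC)ccc2c1=O`) gives > 22000 nM as a limit of the assay and not a number. Compound 2 (`CCOC(=O)c1c(-c2cccc(Cl)c2)[nH]c2cc(OC)ccc2c1=O`) gives > 22000 nM and this is likewise a limit. Compound 3 (`CCOC(=O)c1c(-c2cccc(OC)c2)[nH]c2cc(OC(C)C)ccc2c1=O`) gives > 22000 nM and this too is a limit. Going by the values given here, the picture so far is therefore the limit of > 22000 nM in this assay, at which 3 of the 3 values shown sit, and no compound yet has a number to compare.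

Compound 4 (`CCOC(=O)c1c(-c2cccc(OC)c2)[nH]c2cc(OC)c(F)cc2c1=O`) departs from compound 1 by one change (fluoro in place of hydrogen on an aromatic carbon) in which fluoro takes the place of hydrogen on an aromatic carbon, ortho to a methoxy group. Two measured changes elsewhere on compound 1 bear on it only indirectly. These are chloro in place of methoxy, a step that the two limits leave unreadable from compound 1 to compound 2, and isopropyl in place of methyl on an oxygen, a step that the two limits leave unreadable from compound 1 to compound 3. Among the compounds with values here, neither size can be read, so no step of known size or direction is expected in this assay, and the same limit is the likely outcome. The expected change is a step that the limit leaves unreadable from compound 1 to compound 4 as an estimate only. For compound 4 the estimated value is 30000 nM with an expected range from 15000 nM to 60000 nM in repeat measurements.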

Compound 4, half-maximal effective concentration: > 22000 nM
Compound 4 ended at the assay's limit (the forecaster's own chance of this, stated with the estimate: 85%); the middle value is on the limit's open side.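

Compound 4 gives > 22000 nM in this assay, which is a limit of the assay and not a number. Going by these compounds alone, compound 1 also stands at a limit, so no step from compound 1 to compound 4 can be read. The compounds shown leave open whether any change to the shared core would give a measurable value, as all of them share one result: the limit of > 22000 nM in this assay, at which 4 of the 4 values shown sit.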